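This account rests on a few compounds, and the source may have more. Where it says the series, first, only, none or still open, it means among the compounds named here.

Measured compounds in a functional assay with growth hormone secretagogue receptor type 1 (Homo sapiens) as the target; on this read-out higher numbers stand for larger maximal responses and lower numbers for smaller maximal responses:

compound 1 `COc1cc2c(cc1N1C[C@@H](C)N(C)[C@@H](C)C1)N(S(=O)(=O)c1cccc(Br)c1)CC2` — 0.7
compound 2 `COc1cc2c(cc1N1C[C@@H](C)N(C)[C@@H](C)C1)N(S(=O)(=O)c1ccc3ccccc3c1)CC2` — 0.8

Compound 2 stands highest of the two numbers in this assay; its nearest neighbour is compound 1, and the step a number 0.10 higher from compound 1 to compound 2 (within the scatter) lies within the usual scatter, so the two compounds cannot be ordered on this read-out.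

Compound 3 `COc1cc2c(cc1N1C[C@@H](C)N[C@@H](C)C1)N(S(=O)(=O)c1ccc3ccccc3c1)CC2` is the unmeasured analogue of compound 2. The change is hydrogen in place of methyl on an amine nitrogen in a ring; cut one bond further out it reads 3,4,5-trimethylpiperazin-1-yl to 3,5-dimethylpiperazin-1-yl.

Going by the values given here, only one measured step exists, a number 0.10 higher from compound 1 to compound 2 (within the scatter), and it concerns the group on the sulfonyl sulfur, not the ring nitrogen that is altered here. Among the compounds with values here, no measured step therefore bears directly on the change from compound 2 to compound 3; the data give no basis for predicting a shift in either direction. The working expectation is no step beyond the scatter, a number 0.050 lower from compound 2 to compound 3 (within the scatter), with a widened range to reflect the absence of a matching precedent.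

Compound 3 is accordingly estimated at 0.75 in this assay, with a range from 0.5 to 0.95.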

Compound 3, intrinsic activity: the largest response reached, as a fraction of the reference agonist's: 1
Compound 3: middle estimate off by 0.25, on the low side; the whole stated range lies below it.
By their numbers in this assay, from the lowest: compounds 1 and 2 (each within the scatter of the next); then compound 3.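

In this assay, the amine nitrogen of the ring proves to be a position that matters: hydrogen in place of methyl there, which turns 3,4,5-trimethylpiperazin-1-yl into 3,5-dimethylpiperazin-1-yl, gives a number 0.20 higher from compound 2 to compound 3 (beyond the scatter). Going by these compounds alone, the only earlier step, at the group on the sulfonyl sulfur, was a number 0.10 higher from compound 1 to compound 2 (within the scatter), so this is the first change to leave the scatter, and it shows that removing a single methyl is enough to do so. Within the data shown here, the step is seen only with naphthalen-2-yl on the sulfonyl sulfur, and nothing in the available data accounts for it.

On these data alone, it remains open whether the same change has a similar size with 3-bromophenyl on the sulfonyl sulfur, and what an ethyl or acetyl group on that ring nitrogen would do to the maximal response in this assay. As far as these compounds go, the part played by the two ring methyl groups is also open, and an unsubstituted piperazin-1-yl group in place of 3,5-dimethylpiperazin-1-yl would address it.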